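The compounds below may be only part of what the source reports. "The series", "measured", "known", "first", "only" and "open" are said of these compounds alone.

In a functional assay on KB cells (Homo sapiens) for antiproliferative activity, read by sulforhodamine B assay, with a stated time of 3 days (a lower number here means that less compound is needed, a higher number that more compound is needed for the effect), the three measured compounds stand as follows:

compound 1, `CCC1=C(O)c2c(oc(-c3cccc(C(F)(F)F)c3)cc2=O)C(CC)(CC)C1=O`, gives 35.7 uM;
compound 2, `CCC1=C(O)c2c(oc(-c3cccc(OC)c3)cc2=O)C(CC)(CC)C1=O`, gives 13.3 uM;
compound 3, `CCC1=C(O)c2c(oc(-c3ccccc3C(F)(F)F)cc2=O)C(CC)(CC)C1=O`, gives 45.6 uM.

Compound 2 differs from compound 1 by methoxy in place of trifluoromethyl on an aromatic carbon, and this change brought a 2.7-fold lower number from compound 1 to compound 2 (0.43 log units; beyond the scatter). Compound 3 and compound 1 share the same atoms joined differently; the difference between the two cores is not broken down here. Their values in this assay lie within the scatter of each other, so no order between them is claimed.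

Compound 4, `CCC1=C(O)c2c(oc(-c3ccccc3OC)cc2=O)C(CC)(CC)C1=O`, has not yet been measured. It differs from compound 3 by methoxy in place of trifluoromethyl on an aromatic carbon. Among the measured compounds shown here, this is the same kind of change as the one from compound 1 to compound 2, but the place is not identical: there the group sat meta to a large group, here it sits ortho to a large group. For the measured compounds named here, because the earlier step was a 2.7-fold lower number from compound 1 to compound 2 (0.43 log units; beyond the scatter), compound 4 is expected to follow with a step of similar size, a 2.5-fold lower number from compound 3 to compound 4 (0.40 log units; beyond the scatter), with wider uncertainty since only one example of the change is at hand. The estimate for compound 4 in this assay is 18 uM, between 8 uM and 50 uM.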

Compound 4, concentration for half-maximal effect: 40.8 uM
Estimate against measurement, compound 4: 2.3-fold (0.36 log units) below; the measured number falls inside the stated range.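

In this assay the step to methoxy in place of trifluoromethyl, on an aromatic carbon ortho to a large group, gave a 1.1-fold lower number from compound 3 to compound 4 (0.05 log units; within the scatter) and so shows no readable change on this core, yet this step and the earlier one cannot be told apart: the same change on two cores in this assay, a 2.7-fold lower number (0.43 log units; beyond the scatter) from compound 1 to compound 2 and a 1.1-fold lower number (0.05 log units; within the scatter) from compound 3 to compound 4, 2.4-fold (0.38 log units) apart, within the scatter of two such steps. The position of the methoxy group does leave a readable mark, with 2-methoxyphenyl in place of 3-methoxyphenyl giving a 3.1-fold higher number from compound 2 to compound 4 (0.49 log units; beyond the scatter) in this assay. The series therefore neither shows that the change carries from one core to the other at a constant size nor shows that it fails to carry; each side rests on a single pair of compounds.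

The compounds shown leave open how an amine or a carboxylic acid on the same aromatic carbon would compare with methoxy and trifluoromethyl. They also leave open whether a longer chain in place of the ethyl groups on the shared core would shift these numbers.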